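Aryl swap on the sulfonamide series: plasma protein binding

The source may report more compounds than this note shows. Statements on the series, on what has been measured and on what is new or still open speak of the compounds shown alone.

Measured so far:
Compound 1 `Cn1nccc1-c1cc(C(F)(F)F)ccc1[C@H]1CCc2cc(S(=O)(=O)Nc3ncccn3)ccc21`: 99.7%
Compound 2 `O=S(=O)(Nc1ncccn1)c1ccc2c(c1)OCC[C@@H]2c1ccc(C(F)(F)F)cc1-c1ccc(F)nc1`: 97.1%

In an ADME assay on a cell-free system (plasma, Homo sapiens) for protein binding, compound 2 shows the higher unbound fraction of the two; compound 1 lies at a lower unbound fraction, a gap beyond the scatter. Compound 3 `Cn1nccc1-c1cc(C(F)(F)F)ccc1[C@H]1CCOc2cc(S(=O)(=O)Nc3ncccn3)ccc21` is not yet measured. Against compound 2 it carries 1-methyl-1H-pyrazol-5-yl in place of 6-fluoropyridin-3-yl on an aromatic carbon. Among the compounds with values here, no measured pair isolates this exchange, so the step rests on expectation alone. The step a 3.6-fold lower unbound fraction from compound 2 to compound 3 (0.56 log units; beyond the scatter) is expected to run toward more binding, likely beyond the scatter. For compound 3 the estimate in this assay is 99.2%, with a range of 97.5% to 99.8%.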

Compound 3, plasma protein binding: 95.4%
Compound 3: the middle estimate sits 5.8-fold (0.76 log units) (unbound fraction) below what was measured; the whole stated range lies above it.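

In this assay, placing 1-methyl-1H-pyrazol-5-yl in place of 6-fluoropyridin-3-yl on this aromatic carbon, ortho to a large group, gives a 1.6-fold higher unbound fraction from compound 2 to compound 3 (0.20 log units; within the scatter). Within the data shown here, this is the first pair to isolate the exchange, and on this core the two groups are not separated at this position. No measured evidence bears on this result. The compounds shown leave open whether an amine or a carboxylic acid on this aromatic carbon would give a step beyond the scatter. Also open, from the compounds shown here alone, is whether the same exchange reads alike on the core of compound 1.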